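The source may report more compounds than this note shows. Statements on the series, on what has been measured and on what is new or still open speak of the compounds shown alone.

Measured compounds:
compound 1 `COc1cc(C)cc(-c2nn(CC#N)cc2-c2ccc(-c3cccc(C(C)=O)c3)nc2)c1`, 88%
compound 2 `Cc1cc(O)cc(-c2nn(CC#N)cc2-c2ccnc(-c3ccc(Oc4ccccc4)cc3)c2)c1`, 95%
compound 3 `COc1cc(C)cc(-c2nn(CC#N)cc2-c2ccnc(-c3ccc(N(C)C)cc3)c2)c1`, 102%

All three were tested in a functional assay on T47D cells (Homo sapiens) for cytotoxicity, read by sulforhodamine B assay, with a stated time of 48 h, tested at 0.001 uM (a higher number here means a weaker effect of the compound at the concentration tested, a lower number a stronger effect), and the three numbers lie close together. Compound 2 gives 95%, which is the second highest of the three; compound 1 sits a little lower and compound 3 a little higher, but both gaps fall within the scatter of repeated measurements, so the three compounds cannot be told apart on these numbers. At this very low test concentration none of them shows a marked effect on cell growth.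

The unmeasured compound 4 `Cc1cc(O)cc(-c2nn(CC#N)cc2-c2ccnc(-c3ccc(N(C)C)cc3)c2)c1` is built from compound 2 by a single change: dimethylamino in place of phenoxy on an aromatic carbon. The dimethylamino group that enters is already present in compound 3, which in this assay gives 102%, a number no different in practice from that of compound 2. Within the data shown here, no measured pair differing in just one place is available, so the size of the step has to be judged from the three values alone; the expectation is a step of no more than the scatter, in no particular direction, since compound 3 with the same entering group lies within the scatter of compound 2 at 95%.

For compound 4 the estimate is 98%, with a likely range from 85% to 110%, meaning an expected step of a number 3 percentage points higher from compound 2 to compound 4 (within the scatter) that stays inside the usual scatter.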

Compound 4, a percentage reported as activity, at one concentration (the size of the read-out at that concentration, not a potency): 93%
Beside the measured number, compound 4's estimate is 5 percentage points above it; the range from low to high includes it.
By their numbers in this assay, from the lowest: compounds 1, 4, 2 and 3 (each within the scatter of the next, the first and the last beyond it).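

In this assay the exchange of phenoxy for dimethylamino on an aromatic carbon, para to a large group, gives a number 2 percentage points lower from compound 2 to compound 4 (within the scatter) even though the group that leaves has 7 heavy atoms and a six-membered aromatic ring of carbon only, while the group that enters has 3 heavy atoms and no ring; at this test concentration, a large change in the size of the group at this position therefore leaves the read-out within the scatter. Compound 4 also opens a second comparison in one place, hydrogen in place of methyl on an oxygen on an aromatic ring, which gives a number 9 percentage points lower from compound 3 to compound 4 (within the scatter) and so also stays within the scatter. Nothing measured here explains why either step is so small.

On these data alone, what a carboxylic acid or a longer alkyl chain in place of dimethylamino would give remains open. As far as these compounds go, a read-out at one very low concentration is not a potency, so it also remains open whether these same two changes would separate the compounds at higher concentrations.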